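From Furan to Pyrimidine on the Amide Side Chain

The source may hold more compounds than are shown below. What is called first, only, known or untested is meant among the compounds shown, and "the series" means these compounds.

Measured in an ADME assay on MT4 cells (Homo sapiens) for cytotoxicity, read by MTT assay; a lower number here means that less compound is tolerated, a higher number that more compound is tolerated:
Compound 1 `Cc1cc(C)cc(S(=O)(=O)c2c(C(=O)Nc3ccnc(C#N)c3)[nH]c3ccc(Cl)cc23)c1` gives 6840 nM.
Compound 2 `Cc1cc(C)cc(S(=O)(=O)c2c(C(=O)NC(C)c3ccco3)[nH]c3ccc(Cl)cc23)c1` gives > 54700 nM, which is a limit and not a number.

Compound 2 has no exact value, so it stands only at the limit of > 54700 nM in this assay, at which 1 of the 2 values shown sits. Compound 3 `Cc1cc(C)cc(S(=O)(=O)c2c(C(=O)NC(C)C(=O)NCc3ccncn3)[nH]c3ccc(Cl)cc23)c1` keeps the shared core and changes the side chain of compound 2: ((pyrimidin-4-yl)methyl)carbamoyl in place of furan-2-yl on a saturated chain carbon bound to an amide-type nitrogen and a saturated chain carbon. In words, ((pyrimidin-4-yl)methyl)carbamoyl takes the place of furan-2-yl on a saturated chain carbon bound to an amide-type nitrogen and a saturated chain carbon.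

Within the data shown here, only one measured step bears on this change. It is an at least 7.9-fold higher number from compound 1 to compound 2 (0.90 log units; beyond the scatter), and it shows that the group on the amide-type nitrogen can matter in this assay. That step replaced a different group, however, so it gives no direct size for the new change. Compound 3 is therefore expected to stay close to the limit of compound 2, perhaps slightly lower, with no clear step beyond the scatter. The expected step is an at least 1.2-fold lower number from compound 2 to compound 3 (0.08 log units; that floor lies within the scatter). The assay may well report only a limit again. For compound 3 the estimated value is 45000 nM, with an expected range from 14000 nM to 100000 nM.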

Compound 3, half-maximal cytotoxic concentration: 28100 nM
For compound 3 the middle estimate is 1.6-fold (0.20 log units) above the measured one; low and high end bracket the measured number.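

The value of compound 2 in this assay is a limit and not a number: the limit of > 54700 nM in this assay, at which 1 of the 3 values shown sits.

Against that limit, putting ((pyrimidin-4-yl)methyl)carbamoyl in place of furan-2-yl gives an at least 1.9-fold lower number from compound 2 to compound 3 (0.28 log units; that floor lies within the scatter). The true gap could be larger, but this floor does not by itself establish a real drop, so the change cannot yet be said to make the compound less well tolerated. Among these compounds, the firmer reading is a 4.1-fold higher number from compound 1 to compound 3 (0.61 log units; beyond the scatter), which adds a second exact comparison to the earlier one-sided step: both side chains with a saturated chain carbon on the amide-type nitrogen, the one in compound 2 and the one in compound 3, give higher numbers than the 2-cyanopyridin-4-yl group of compound 1.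

The compounds shown do not separate the carbamoyl link from the pyrimidine ring, since the two enter together in compound 3. As far as these compounds go, it also remains open whether a carboxylic acid, a plain amine or a longer chain on the same saturated chain carbon would read closer to compound 2 or to compound 1.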